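Replacing a Trifluoroethyl Tail with an Aminoalkyl Carbonyl Chain

The source may report more compounds than this note shows. Statements on the series, on what has been measured and on what is new or still open speak of the compounds shown alone.

Compound 2 `CCc1cccc2c(OC)c(-c3occ(C)c3COCC(F)(F)F)ccc12` has been tested in a functional assay on KBVIN cells (Homo sapiens) for cytotoxicity, read by MTT assay, with a stated time of 72 h (a higher number here means that more compound is needed for the effect, a lower number that less compound is needed), where compound 2 gives 6 ug/mL. Going by the values given here, its only measured neighbour, compound 1 `CCc1cccc2c(OC)c(-c3occ(C)c3COC)ccc12`, gives 8.8 ug/mL in this assay, and the step of a 1.5-fold lower number from compound 1 to compound 2 (0.17 log units; within the scatter) shows the two numbers lie within the usual scatter of each other. Compound 3 `CCc1cccc2c(OC)c(-c3occ(C)c3COC(=O)CCN(CC)CC)ccc12` differs from compound 2 by (2-(diethylamino)ethyl)carbonyl in place of 2,2,2-trifluoroethyl on an oxygen on a saturated carbon. Among the compounds with values here, the single measured step touches the same chain end and stayed within the scatter, so no larger shift is expected. Compound 3 is therefore estimated at 7 ug/mL, in a range from 2.5 ug/mL to 20 ug/mL, meaning an expected 1.2-fold higher number from compound 2 to compound 3 (0.07 log units; within the scatter).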

Compound 3, concentration for half-maximal effect: > 10 ug/mL
Compound 3: only a limit was reported; the forecaster's own chance of this, stated with the estimate: 10%; middle value at least 1.4-fold (0.15 log units) away from the limit.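

Compound 3 is reported only as a limit in this assay: the limit of > 10 ug/mL in this assay, at which 1 of the 3 values shown sits. Placing (2-(diethylamino)ethyl)carbonyl on this oxygen gives an at least 1.6-fold higher number from compound 2 to compound 3 (0.22 log units; that floor lies within the scatter), and measured against the methyl group it gives an at least 1.1-fold higher number from compound 1 to compound 3 (0.05 log units; that floor lies within the scatter). On these data alone, both floors lie within the scatter, so the true size of this change stays unknown, but unlike the earlier pair, it brings no sign of a lower number.

As far as these compounds go, whether the carbonyl or the diethylamino end matters more remains open. A plain acetyl group on the same oxygen would separate the two.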